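The compounds below may be only part of what the source reports. "The series", "measured", "known", "first", "only" and "open" are said of these compounds alone.

Of the compounds shown here, three that share one core have been tested in an assay on isolated protein (Oryctolagus cuniculus) with Thromboxane-A synthase (Homo sapiens) as the target, tested at 1 uM; a lower number here means less inhibition, a higher number more inhibition at the concentration tested (going by the name of the read-out). Compound 1 `O=c1c2ccccc2c(-c2cccnc2)nn1C1CCCC1` carries a cyclopentyl on an aromatic nitrogen, and in this assay compound 1 gives 97%. Compound 2 `CCOC(=O)Cn1nc(-c2cccnc2)c2ccccc2c1=O` carries an (ethoxycarbonyl)methyl at the same place, and compound 2 gives 28%. Compound 3 `CCOC(=O)CCCn1nc(-c2cccnc2)c2ccccc2c1=O` carries a 3-(ethoxycarbonyl)propyl there, and compound 3 gives 95%. Among these three numbers compound 3 stands second highest: its nearest neighbour is compound 1, and the step of a number 2 percentage points lower from compound 1 to compound 3 (within the scatter) lies within the scatter, while the step of a number 67 percentage points higher from compound 2 to compound 3 (beyond the scatter) is large.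

Compound 4 `O=C(c1cccs1)n1nc(-c2cccnc2)c2ccccc2c1=O` is the next compound, not yet measured. It differs from compound 3 as follows: (thiophen-2-yl)carbonyl in place of 3-(ethoxycarbonyl)propyl on an aromatic nitrogen. The measured steps that bear on this are a number 69 percentage points lower from compound 1 to compound 2 (beyond the scatter) and a number 67 percentage points higher from compound 2 to compound 3 (beyond the scatter): both show that a short group bearing a carbonyl placed close to the aromatic nitrogen goes with a much lower number, whereas the longer chain and the cyclopentyl give high numbers. Compound 4 sets a carbonyl directly on the aromatic nitrogen, which resembles compound 2 more than compound 3. A downward step in this assay is therefore expected, of the size a number 55 percentage points lower from compound 3 to compound 4 (beyond the scatter). Compound 4 is estimated at 40%, with a range from 10% to 85%.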

Compound 4, a percentage reported as inhibition, at one concentration (the size of the read-out at that concentration, not a potency): 37%
Estimate against measurement, compound 4: 3 percentage points above, within the range that was stated.
By their numbers in this assay, from the lowest: compounds 2 and 4 (each within the scatter of the next); then compounds 3 and 1 (each within the scatter of the next).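

In this assay, the step of a number 58 percentage points lower from compound 3 to compound 4 (beyond the scatter) and the step of a number 60 percentage points lower from compound 1 to compound 4 (beyond the scatter) show that this position can lose most of its inhibition with a group that contains no ester, while the step of a number 9 percentage points higher from compound 2 to compound 4 (within the scatter) puts (thiophen-2-yl)carbonyl level with (ethoxycarbonyl)methyl. The ester is therefore not needed for the low number, and a ring in the group does not secure a high one, as cyclopentyl and (thiophen-2-yl)carbonyl both carry a ring and stand far apart. The large change from compound 3 to compound 4 also comes with little change in what is counted, 7 heavy atoms entering for 8 leaving and hydrogen-bond acceptors and donors unchanged, and nothing measured here accounts for the difference.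

From the compounds shown here alone, it remains open whether the low numbers of compound 2 and compound 4 follow from a carbonyl close to the aromatic nitrogen, or whether the thiophene ring itself plays a part. A cyclopentylcarbonyl group, a thiophen-2-ylmethyl group, or a carboxylic acid at the end of the propyl chain would each test a different part of this.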